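The source may hold more compounds than are shown below. What is called first, only, known or untested is meant among the compounds shown, and "the series" means these compounds.

Compound 1 `CN(CCC#N)C[C@H]1CN(c2ccc(-n3cc(-c4ccccn4)cn3)c(F)c2)C(=O)O1`: in an ADME assay on HEK293-A cells (Homo sapiens) for cytotoxicity, read by MTT assay, with a stated time of 48 h (a higher number here means a weaker inhibitor, a lower number a stronger inhibitor), compound 1 gives > 400 ug/mL, a limit of the assay.
Compound 2 `CC(=O)OC[C@H]1CN(c2ccc(-n3cc(-c4ccccn4)cn3)c(F)c2)C(=O)O1`: compound 2 gives > 400 ug/mL, also a limit of the assay.
Compound 3 `O=C1O[C@@H](Cn2ccnn2)CN1c1ccc(-n2cc(-c3ccccn3)cn2)c(F)c1`: compound 3 gives 225 ug/mL.

Among these three, compound 3 holds the only actual number in this assay; the other two values stop at the limit of > 400 ug/mL in this assay, at which 2 of the 3 values shown sit. Compound 4 `COC(=O)NC[C@H]1CN(c2ccc(-n3cc(-c4ccccn4)cn3)c(F)c2)C(=O)O1` differs from compound 3 in one place: (methoxycarbonyl)amino in place of 1H-1,2,3-triazol-1-yl on a saturated chain carbon bound to a saturated ring carbon. Two measured steps reach compound 3 from the other side. There is an at least 1.7-fold lower number from compound 1 to compound 3 (0.24 log units; that floor lies within the scatter) and an at least 1.7-fold lower number from compound 2 to compound 3 (0.24 log units; that floor lies within the scatter), both of which are only floors that lie within the scatter. The step that the two limits leave unreadable from compound 1 to compound 2 cannot be read at all. So two different groups at this position both gave a limit, while the triazole gave a number; replacing the triazole with a third group is expected to move the value back toward, or onto, that limit. The expected step is a 1.6-fold higher number from compound 3 to compound 4 (0.19 log units; within the scatter), and compound 4 is estimated at 350 ug/mL, with a range from 180 ug/mL to 800 ug/mL.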

Compound 4, half-maximal inhibitory concentration: 306 ug/mL
Compound 4: middle estimate off by 1.1-fold (0.06 log units), on the high side; low and high end bracket the measured number.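

In this assay there is a 1.4-fold higher number from compound 3 to compound 4 (0.13 log units; within the scatter), so the open-chain (methoxycarbonyl)amino group, with no ring and one hydrogen-bond donor, also gives an actual number, and it cannot be told apart from the triazole. Set against the other two groups, there is an at least 1.3-fold lower number from compound 2 to compound 4 (0.11 log units; that floor lies within the scatter) and an at least 1.3-fold lower number from compound 1 to compound 4 (0.11 log units; that floor lies within the scatter), and both of these are only floors. Compound 1 and compound 2 each stop at a limit of the assay, so how far they truly lie from compound 4 stays unknown: the limit of > 400 ug/mL in this assay, at which 2 of the 4 values shown sit.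

As far as these compounds go, whether a primary amine or a carboxylic acid on this saturated chain carbon would give a number that differs beyond the scatter stays open. All four compounds share one core, so they also cannot tell how much of the value comes from that core.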